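The source may report more compounds than this note shows. Statements on the series, on what has been measured and on what is new or still open speak of the compounds shown alone.

Measured compounds in the series:

- compound 1 `CS(=O)(=O)c1ccc(C(=O)NCCC(=O)N2CCCCC2)cc1[N+](=O)[O-]` — > 60000 nM in an assay on isolated protein for inhibition of vitamin D3 receptor (Homo sapiens), read by fluorescence polarization; a higher number here means a weaker inhibitor, a lower number a stronger inhibitor
- compound 2 `CS(=O)(=O)c1ccc(C(=O)NCCC(=O)N2CCc3ccccc32)cc1[N+](=O)[O-]` — > 60000 nM in this assay

Both values are limits of this assay, not numbers. For compound 1 the value > 60000 nM is a limit. For compound 2 the value > 60000 nM is likewise a limit. Compound 2 therefore stands at the limit of > 60000 nM in this assay, at which 2 of the 2 values shown sit, with nothing in the series to set it apart from compound 1; the step that the two limits leave unreadable from compound 1 to compound 2 cannot be read, since both ends sit at the same limit.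

Compound 3 `CC1CCN(C(=O)CCNC(=O)c2ccc(S(C)(=O)=O)c([N+](=O)[O-])c2)CC1` has not yet been measured in this assay. It differs from compound 2 as follows: 4-methylpiperidin-1-yl in place of 2,3-dihydro-1H-indol-1-yl on a carbonyl carbon. Going by the values given here, the only measured step, a step that the two limits leave unreadable from compound 1 to compound 2, is the one that bears on this change, and it gives no readable size, so no direction can be drawn from it. Since compound 1 and compound 2 both sit at the limit, compound 3 is expected to do the same, with a step that the limit leaves unreadable from compound 2 to compound 3 that is expected to remain unreadable. Compound 3 is estimated at 80000 nM, in the range 30000 nM to 200000 nM, most likely again reported only as a limit.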

Compound 3, half-maximal inhibitory concentration: > 60000 nM
Compound 3 gave a limit, no number (the forecaster's own chance of this, stated with the estimate: 85%); the middle value does not contradict the limit.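

No new step can be read among compound 1, compound 2 and compound 3, as all three are reported only as limits, not numbers: the limit of > 60000 nM in this assay, at which 3 of the 3 values shown sit.

The compounds shown leave open whether piperidin-1-yl, 2,3-dihydro-1H-indol-1-yl and 4-methylpiperidin-1-yl on the carbonyl carbon differ at all in this assay.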